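The source may report more compounds than this note shows. Statements on the series, on what has been measured and on what is new or still open speak of the compounds shown alone.

Compound 3 `CCC(C)[C@H](NC(=O)[C@]1(O)C[C@@H](O)[C@@H](O)[C@H](O)C1)C(=O)O` carries a sec-butyl on a saturated chain carbon bound to an amide-type nitrogen and a carbonyl carbon. In an assay on HL-60 cells for inhibition of E-selectin (Homo sapiens) (on this read-out lower numbers stand for stronger inhibition and higher numbers for weaker inhibition), compound 3 gives only a limit, > 50000000 nM. Compound 1 `O=C(O)CNC(=O)[C@]1(O)C[C@@H](O)[C@@H](O)[C@H](O)C1` likewise gives only a limit in this assay, > 50000000 nM. Compound 2 `O=C(O)CCCNC(=O)[C@]1(O)C[C@@H](O)[C@@H](O)[C@H](O)C1` also stops at a limit in this assay, > 50000000 nM. All three values therefore sit at the same point, (the limit of > 50000000 nM in this assay, at which 3 of the 3 values shown sit), and the two measured steps, a step that the two limits leave unreadable from compound 1 to compound 2 and a step that the two limits leave unreadable from compound 1 to compound 3, cannot be read as to size or direction. Compound 4 `O=C(O)[C@H](CO)NC(=O)[C@]1(O)C[C@@H](O)[C@@H](O)[C@H](O)C1` is not yet measured; it differs from compound 3 by hydroxymethyl in place of sec-butyl on a saturated chain carbon bound to an amide-type nitrogen and a carbonyl carbon. Among the measured compounds shown here, no measured step bears on this change with a readable size, and no change so far has moved any compound off the limit. Compound 4 is therefore expected to remain at the limit as well, the step being estimated as a number no higher from compound 3 to compound 4 (the limit leaves the size open). The estimate for compound 4 is 50000000 nM, within 10000000 nM to 200000000 nM.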

Compound 4, half-maximal inhibitory concentration: > 50000000 nM
Compound 4 was reported as a limit; the forecaster's own chance of this, stated with the estimate: 90%; the middle value lies on the limit itself.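

Compound 4 also stops at a limit in this assay, > 50000000 nM. Its steps from compound 1, compound 2 and compound 3 therefore cannot be read: the limit of > 50000000 nM in this assay, at which 4 of the 4 values shown sit.

The compounds shown leave open whether any change on the shared core moves a compound off this limit.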